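Urea to cyclic urea in the stilbene series

The compounds below may be only part of what the source reports. "The series", "measured", "known", "first", "only" and "open" are said of these compounds alone.

Values in a functional assay on HT-29 cells (Homo sapiens) for inhibition, read by sulforhodamine B assay, with a stated time of 48 h; a higher number here means a weaker inhibitor, a lower number a stronger inhibitor:
- compound 1 `CCNC(=O)Nc1ccc(/C=C\c2cccc(Cl)c2)cc1`: 26000 nM
- compound 2 `CCNC(=O)Nc1ccc(/C=C\c2cc(OC)c(OC)c(OC)c2)cc1`: 21000 nM
- compound 3 `Cc1cc(C)cc(/C=C/c2ccc(N3CCNC3=O)cc2)c1`: 14000 nM

In this assay compound 2 gives 21000 nM, within the scatter of both compound 1 and compound 3. Compound 4 `COc1cc(/C=C\c2ccc(N3CCNC3=O)cc2)cc(OC)c1OC` is not yet measured. It carries 2-oxoimidazolidin-1-yl in place of (ethylcarbamoyl)amino on an aromatic carbon, para to a large group: 2-oxoimidazolidin-1-yl in place of (ethylcarbamoyl)amino on an aromatic carbon. Among the measured compounds shown here, no measured pair isolates this change. Compound 3, which also carries 2-oxoimidazolidin-1-yl, gives 14000 nM, so only a small step towards a lower number, or none beyond the scatter, is expected. The expected change is a 1.8-fold lower number from compound 2 to compound 4 (0.24 log units; within the scatter). For compound 4 the estimated value is 12000 nM, with an expected range from 3000 nM to 30000 nM.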

Compound 4, half-maximal inhibitory concentration: 1.7 nM
Estimate against measurement, compound 4: 7100-fold (3.85 log units) above; the whole stated range lies above it.
By their numbers in this assay, from the lowest: compound 4; then compounds 3, 2 and 1 (each within the scatter of the next).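

In this assay, among the compounds shown here, the exchange of (ethylcarbamoyl)amino for 2-oxoimidazolidin-1-yl gives a 12000-fold lower number from compound 2 to compound 4 (4.09 log units; beyond the scatter) and is the only single-place change, so this aromatic position is highly sensitive to the exchange. Heavy-atom count stays the same, so the step accompanies ring closure and the change from 2 hydrogen-bond donors to 1, not a change in atom count. No measurement on hand explains the step. As far as these compounds go, whether the ring or the lost donor matters remains open; a methyl group on the remaining ring nitrogen and a six-membered cyclic urea would both bear on this.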